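The compounds below may be only part of what the source reports. "The series", "measured", "known", "first", "only" and "open" are said of these compounds alone.

Measured compounds:
- compound 1, `Cc1nn(-c2ncnc3nc[nH]c23)c2c1C(OCc1ccc(C(C)C)cc1)CC(=O)N2`: in a functional assay on HEK293 cells for agonist activity at G-protein coupled receptor 39 (Homo sapiens), read by scintillation proximity assay and inositol phosphate accumulation, with a stated time of 75 min, in the presence of a further agent that is not named here (a lower number here means that less compound is needed, a higher number that more compound is needed for the effect), compound 1 gives 5 nM
- compound 2, `Cc1nn(-c2ncnc3nc[nH]c23)c2c1C(OCc1cc(F)cc3c1OCOC3)CC(=O)N2`: in this assay compound 2 gives 1.5 nM

Compound 2 holds the lowest of the two numbers shown in this assay, with compound 1 as its only neighbour, separated by a 3.3-fold lower number from compound 1 to compound 2 (0.52 log units; beyond the scatter). Compound 3, `Cc1nn(-c2ncnc3nc[nH]c23)c2c1C(OCC(C)C)CC(=O)N2`, has not yet been measured in this assay. Relative to compound 2 it carries a group of 3 heavy atoms (3 carbon; no ring) in place of a group of 11 heavy atoms (8 carbon, 2 oxygen, 1 fluorine; one six-membered non-aromatic ring with 2 hetero atoms, one six-membered aromatic ring of carbon only), on a saturated chain carbon bound to an oxygen on a saturated carbon. Within the data shown here, only one measured step touches this position: from compound 1 to compound 2 the group on that chain carbon was exchanged for another, both containing an aromatic ring, and the result was a 3.3-fold lower number from compound 1 to compound 2 (0.52 log units; beyond the scatter). Among the measured compounds shown here, compound 3 goes further, since the isopropyl brings no ring at all, so no measured step covers a change of this kind. That the exchange of one ring-bearing group for another already moved the number beyond the scatter suggests the position is sensitive, and the removal of the whole ring-bearing group is expected to raise the number in this assay more clearly, as a 20-fold higher number from compound 2 to compound 3 (1.30 log units; beyond the scatter). Compound 3 is therefore expected to give about 30 nM, with a range from 5 nM to 200 nM.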

Compound 3, half-maximal effective concentration: 4 nM
Estimate against measurement, compound 3: 7.5-fold (0.88 log units) above; measured number outside the range, below it.
By their numbers in this assay, from the lowest: compound 2; then compounds 3 and 1 (each within the scatter of the next).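

In this assay the position proves far less demanding than the earlier pair suggested: a group with no ring at all, isopropyl, replaces the large two-ring group with only a 2.7-fold higher number from compound 2 to compound 3 (0.43 log units; beyond the scatter). Set against 4-isopropylphenyl, the same isopropyl gives a 1.3-fold lower number from compound 1 to compound 3 (0.10 log units; within the scatter), so among these compounds the carbon-only aromatic ring on this saturated chain carbon can be lost without a change that stands out from the scatter, and only the two-ring group of compound 2 keeps its number apart from the other two. Nothing available here explains why this position accepts such a loss of heavy atoms.

The compounds shown leave open how far the group on this carbon can vary while the number stays low, for example with a methyl, a longer chain such as n-hexyl, an amine or a carboxylic acid. They also leave open whether the fluorine or the non-aromatic ring with its two oxygens accounts for the separate number of compound 2, as the two appear here only together.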